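The source may report more compounds than this note shows. Statements on the series, on what has been measured and on what is new or still open speak of the compounds shown alone.

In an ADME assay on Huh-7 cells (Homo sapiens) for cytotoxicity, read by MTT assay, with a stated time of 3 days (a higher number here means that more compound is tolerated, a lower number that less compound is tolerated), compound 1 (`CCCCc1cn(-c2ccc(NC(=O)Nc3ccccc3C)cc2)nn1`) gives > 200000 nM, which is a limit of the assay and not a number. Compound 2 (`CCCCc1cn(-c2cccc(S(=O)(=O)Nc3ccccc3O)c2)nn1`) gives > 200000 nM, again a limit. Compound 3 (`CCCCc1cn(-c2cccc(S(=O)(=O)Nc3ccccc3F)c2)nn1`) gives > 200000 nM, also a limit. Compound 3 therefore has no exact place on the scale, and the overall picture is the limit of > 200000 nM in this assay, at which 3 of the 3 values shown sit.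

Compound 4 (`CCCCc1cn(-c2cccc(S(=O)(=O)Nc3ccccc3C)c2)nn1`) has not yet been measured. It differs from compound 3 by methyl in place of fluoro on an aromatic carbon, ortho to a large group: methyl in place of fluoro on an aromatic carbon.

Going by the values given here, one measured step bears on this change, because it also swaps a single group on an aromatic carbon: a step that the two limits leave unreadable from compound 2 to compound 3. It offers a direction and size for neither the earlier swap nor the new one. What remains is the shared limit, with all three measured compounds sitting there and none going against it.

Resting on compound 3 and that shared limit, (the limit of > 200000 nM in this assay, at which 3 of the 3 values shown sit), the expected step of a number no higher from compound 3 to compound 4 (the limit leaves the size open) is none beyond the scatter. The assay will most likely report only a limit again. For compound 4 the estimated value is 200000 nM, with an expected range from 100000 nM to 400000 nM.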

Compound 4, half-maximal cytotoxic concentration: > 200000 nM
Compound 4 gave a limit, no number; the forecaster's own chance of this, stated with the estimate: 85%; the middle value lies on the limit itself.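

In this assay compound 4 gives > 200000 nM and this is a limit, not a number. Compound 2 and compound 3 also sit at a limit, so no step among these three compounds can be read. The compounds shown leave open at what concentration any of them harms these cells, and whether hydroxy, fluoro or methyl makes any difference to it: the limit of > 200000 nM in this assay, at which 4 of the 4 values shown sit.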